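The source may hold more compounds than are shown below. What is called first, only, known or untested is meant among the compounds shown, and "the series" means these compounds.

Measured in a functional assay on Raji cells (Homo sapiens) for cytotoxicity, with a stated time of 72 h; on this read-out lower numbers stand for an effect already at smaller amounts and higher numbers for an effect only at larger amounts of compound:
- compound 1 `COc1ccc(/C=C/[C@@](C)(/C=C/c2ccc(O)cc2)CCC=C(C)C)cc1`: > 26000 nM
- compound 2 `CCOc1ccc(/C=C/[C@@](C)(/C=C/c2ccc(O)cc2)CCC=C(C)C)cc1`: > 26000 nM

Neither entry is a number, and each is a limit of the assay. The picture so far is the limit of > 26000 nM in this assay, at which 2 of the 2 values shown sit. Compound 2 has only a limit, > 26000 nM. Compound 3 `CC(C)=CCC[C@@](C)(/C=C/c1ccccc1)/C=C/c1ccc(O)cc1` differs from it by hydrogen in place of ethoxy on an aromatic carbon, with hydrogen in place of ethoxy on an aromatic carbon. Going by the values given here, the one measured step, a step that the two limits leave unreadable from compound 1 to compound 2, touches the same group but gives no size to carry over. No step beyond the scatter is therefore expected in this assay, and no direction. Compound 3 is expected near 30000 nM, with an estimated range of 13000 nM to 60000 nM. The expected step is a step that the limit leaves unreadable from compound 2 to compound 3.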

Compound 3, half-maximal effective concentration: > 26000 nM
Compound 3: a limit, no number; the forecaster's own chance of this, stated with the estimate: 75%; the middle value is on the limit's open side.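

Going by these compounds alone, compound 3 gives > 26000 nM, which is a limit and not a number, so no step among compound 1, compound 2 and compound 3 can be read. From the compounds shown here alone, whether methoxy, ethoxy or hydrogen on that aromatic carbon differ in effect stays open.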